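A few compounds are considered here, and "the series" means these few. Any claim that something is new, unique, unknown or untested is made for them only; others in the source may bear on it.

Working notes on the series. Of the compounds shown here, three sharing one core have been measured in a functional assay on HL-60 cells (Homo sapiens) for antiproliferative activity; on this read-out higher numbers stand for weaker inhibition and lower numbers for stronger inhibition. Compound 1 `C=C1C(=O)ON(C)C1C(C)CCC` gives 4700 nM. Compound 2 `C=C1C(=O)ON(C)C1c1ccccc1` gives 34800 nM, and compound 3 `C=C1C(=O)ON(C)C1c1ccc(C)cc1` gives 5400 nM. On these three numbers compound 3 holds the second highest; its gap to compound 1 lies within the scatter, so the two cannot be ordered, while compound 2 sits clearly apart, the measured step being a 6.4-fold lower number from compound 2 to compound 3 (0.81 log units; beyond the scatter), a modest step and the only one so far that touches the aromatic ring.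

Compound 4 `C=C1C(=O)ON(C)C1c1ccc(OC)cc1` has not yet been measured in this assay. It differs from compound 3 in one place: methoxy in place of methyl on an aromatic carbon. Among the measured compounds shown here, the one measured step at this position went from hydrogen to methyl and lowered the number beyond the scatter; there is no measured step from methyl to methoxy anywhere, so the expectation rests only on the fact that a small group at this position was tolerated in compound 3. The step from compound 3 to compound 4 is therefore expected to be small, a 1.1-fold higher number from compound 3 to compound 4 (0.05 log units; within the scatter), likely within the scatter and with no confident direction. Compound 4 is estimated at 6000 nM, with a range from 2000 nM to 18000 nM.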

Compound 4, half-maximal inhibitory concentration: 5400 nM
The estimate for compound 4 lay 1.1-fold (0.05 log units) above the measured number; low and high end bracket the measured number.
By their numbers in this assay, from the lowest: compounds 1, 3 and 4 (each within the scatter of the next); then compound 2.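

In this assay, methoxy in place of methyl on this aromatic carbon gives no change at the digits printed from compound 3 to compound 4 (within the scatter), so the two groups cannot be told apart at this position, even though methoxy enters with one more heavy atom and a hydrogen-bond acceptor. Methoxy in place of hydrogen gives a 6.4-fold lower number from compound 2 to compound 4 (0.81 log units; beyond the scatter), matching in size the earlier step of a 6.4-fold lower number from compound 2 to compound 3 (0.81 log units; beyond the scatter), which shows that the lower number is not tied to methyl alone but is shared by two different groups on this carbon. Nothing at hand accounts for this result.

The compounds shown leave open how far this tolerance extends: an amine, a carboxylic acid, a chlorine atom or a longer chain such as butoxy on the same carbon might read like methyl and methoxy or might return towards the number of the unsubstituted ring of compound 2. They also leave open whether methoxy would give the same result on another carbon of the ring, since every substituted aromatic compound in the series carries its group at this one position.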